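Stretching the Chain Between Amide and Imidazole

The source may report more compounds than this note shows. Statements on the series, on what has been measured and on what is new or still open speak of the compounds shown alone.

Measured compounds:
compound 1 `O=C(NCCCCCCn1ccnc1)c1ccc(Cl)s1`: 200 nM
compound 2 `O=C(NCCCCCn1ccnc1)c1ccc(Cl)s1`: 200 nM

In an assay on isolated protein for inhibition of Thromboxane-A synthase (Rattus norvegicus) (a lower number here means a stronger inhibitor, a higher number a weaker inhibitor), compound 1 gives 200 nM, and compound 2 gives 200 nM, so compound 1 stands level with compound 2. Among the measured compounds shown here, the one step measured, no change at the digits printed from compound 1 to compound 2 (within the scatter), shortens the chain by one carbon and leaves the read-out unchanged within the scatter. Compound 3 `O=C(NCCCCCCCCn1ccnc1)c1ccc(Cl)s1` goes the other way: 2-(1H-imidazol-1-yl)ethyl in place of 1H-imidazol-1-yl on a saturated chain carbon, six bonds along the chain from an amide-type nitrogen. For the measured compounds named here, since the one step known shows the chain length tolerated, no step beyond the scatter is expected, a 1.3-fold higher number from compound 1 to compound 3 (0.10 log units; within the scatter). Compound 3 is therefore estimated at 250 nM, between 80 nM and 800 nM.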

Compound 3, half-maximal inhibitory concentration: 70 nM
Estimate against measurement, compound 3: 3.6-fold (0.55 log units) above, and the stated range ends above it.
By their numbers in this assay, from the lowest: compound 3; then compounds 1 and 2 (each within the scatter of the next).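

The chain at this position is not indifferent to length: 2-(1H-imidazol-1-yl)ethyl in place of 1H-imidazol-1-yl gives a 2.9-fold lower number from compound 1 to compound 3 (0.46 log units; beyond the scatter) in this assay, a modest step beyond the scatter, whereas the earlier step, no change at the digits printed from compound 1 to compound 2 (within the scatter), showed no such movement. The lower number therefore appears only with the longer chain of compound 3. Nothing measured here accounts for this difference. Going by these compounds, it remains open whether a still longer chain would lower the number further, and how a carboxylic acid in place of 1H-imidazol-1-yl would read in this assay.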